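The compounds below may be only part of what the source reports. "The series", "measured", "known", "first", "only" and "open" are said of these compounds alone.

Measured in a functional assay on K562 cells (Homo sapiens) for inhibition, read by MTT assay, with a stated time of 72 h; on this read-out higher numbers stand for weaker inhibition and lower numbers for stronger inhibition:
Compound 1 `CC(C)c1ccc(C(=O)/C=C/C(=O)O)c(C(C)C)c1`: 4680 nM
Compound 2 `O=C(O)/C=C/C(=O)c1ccc(Cl)cc1`: 21700 nM
Compound 3 `O=C(O)/C=C/C(=O)c1ccccc1`: 30200 nM

Compound 3 gives the highest of the three numbers. Its nearest neighbour is compound 2, and the one-place step a 1.4-fold higher number from compound 2 to compound 3 (0.14 log units; within the scatter) is small. Compound 1, which carries two isopropyl groups, gives the lowest number of the three, clearly apart from compound 3.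

Compound 4 `CC(C)c1ccc(C(=O)/C=C/C(=O)O)cc1` differs from compound 3 by isopropyl in place of hydrogen on an aromatic carbon. Within the data shown here, no measured step adds an isopropyl alone; the sole one-place step, a 1.4-fold higher number from compound 2 to compound 3 (0.14 log units; within the scatter), concerns a different group and lies within the scatter. The values of compound 1 and compound 3 suggest that isopropyl groups go with lower numbers, so a moderate drop is expected for compound 4, a 2.3-fold lower number from compound 3 to compound 4 (0.37 log units; beyond the scatter). Compound 4 is estimated at 13000 nM, with a range of 5000 nM to 32000 nM.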

Compound 4, half-maximal inhibitory concentration: 5560 nM
For compound 4 the middle estimate is 2.3-fold (0.37 log units) above the measured one; the range from low to high includes it.
By their numbers in this assay, from the lowest: compounds 1 and 4 (each within the scatter of the next); then compounds 2 and 3 (each within the scatter of the next).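

In this assay, isopropyl on the aromatic carbon para to a group of 7 heavy atoms gives a 5.4-fold lower number from compound 3 to compound 4 (0.73 log units; beyond the scatter). Isopropyl in place of chloro at that carbon gives a 3.9-fold lower number from compound 2 to compound 4 (0.59 log units; beyond the scatter), so this change moves the number, whereas the change from chloro to hydrogen stays within the scatter. The second isopropyl of compound 1 makes no readable difference, with a 1.2-fold higher number from compound 1 to compound 4 (0.07 log units; within the scatter).

Nothing at hand gives a reason for these steps. On these data alone, whether a longer chain or an amine at this carbon would give a similar step remains open.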